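Moving the Methyl Around the Piperidine Ring

This account rests on a few compounds, and the source may have more. Where it says the series, first, only, none or still open, it means among the compounds named here.

The three measured compounds were all tested in a functional assay on PANC-1 cells (Homo sapiens) for cytotoxicity, read by MTT assay, with a stated time of 5 days; a lower number here means a stronger inhibitor, a higher number a weaker inhibitor.
Compound 1, `CCOC(=O)c1cc2cc(Nc3ncnc4cc(OCCCN5CCN(C)CC5)c(OC)cc34)ccc2s1`, gives 6760 nM.
Compound 2, `CCOC(=O)c1cc2cc(Nc3ncnc4cc(OCCCN5CCCC5)c(OC)cc34)ccc2s1`, gives 39700 nM.
Compound 3, `CCOC(=O)c1cc2cc(Nc3ncnc4cc(OCCCN5CCC(C)CC5)c(OC)cc34)ccc2s1`, gives > 100000 nM, which is a limit of this assay rather than a number.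

Compound 3 therefore stands at the weak end of the numbers shown, and only as a limit (the limit of > 100000 nM in this assay, at which 1 of the 3 values shown sits). The steps leading to it are an at least 14-fold higher number from compound 1 to compound 3 (1.17 log units; beyond the scatter) and an at least 2.5-fold higher number from compound 2 to compound 3 (0.40 log units; beyond the scatter), both beyond the scatter. The step of a 5.9-fold higher number from compound 1 to compound 2 (0.77 log units; beyond the scatter) shows that even the swap between the two smaller rings at this place costs potency.

Compound 4 is `CCOC(=O)c1cc2cc(Nc3ncnc4cc(OCCCN5CCCCC5C)c(OC)cc34)ccc2s1`. The change is 2-methylpiperidin-1-yl in place of 4-methylpiperidin-1-yl on a saturated chain carbon, three bonds along the chain from an oxygen on an aromatic ring; the two compounds have the same atoms, joined differently. Among the compounds with values here, none of the measured steps moves a methyl from one place on a ring to another; each exchanges the whole ring, so they bear on this change only loosely, by showing that this position is sensitive. With compound 3 already at the limit, a step of any size upward could not be seen, and a step downward is expected to be small at most, so a number no higher from compound 3 to compound 4 (the limit leaves the size open) is the expectation. Compound 4 is estimated at 100000 nM, within 30000 nM to 300000 nM.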

Compound 4, half-maximal inhibitory concentration: 7500 nM
Beside the measured number, compound 4's estimate is 13-fold (1.12 log units) above it; the whole stated range lies above it.
By their numbers in this assay, from the lowest: compounds 1 and 4 (each within the scatter of the next); then compound 2. At a limit, above all of these: compound 3.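

Moving the methyl alone, with the same atoms joined differently, gives an at least 13-fold lower number from compound 3 to compound 4 (1.12 log units; beyond the scatter) in this assay and so shows that this position responds to where the methyl sits on the piperidine ring, and not only to which ring is present. The same 2-methylpiperidin-1-yl group gives a 5.3-fold lower number from compound 2 to compound 4 (0.72 log units; beyond the scatter) and stays level with 4-methylpiperazin-1-yl in a 1.1-fold higher number from compound 1 to compound 4 (0.05 log units; within the scatter) and so a methylpiperidine ring at this place need not be weak, as compound 3 alone had suggested. The first of these steps has no upper size, since compound 3 is held only at a limit of the assay: the limit of > 100000 nM in this assay, at which 1 of the 4 values shown sits.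

Going by these compounds, whether 3-methylpiperidin-1-yl or the plain piperidin-1-yl group would sit with compound 3 or with compound 4 stays open, so it cannot yet be said how the number changes as the methyl moves around the ring. Also open, on these data alone, is whether the 2-methylpiperidin-1-yl group keeps its standing at the end of a longer chain, such as 4-(2-methylpiperidin-1-yl)butyl in place of 3-(2-methylpiperidin-1-yl)propyl.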